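The compounds below may be only part of what the source reports. "The series", "measured", "known", "first", "only" and "open" are said of these compounds alone.

Three compounds have been measured so far in a functional assay on HOP-62 cells (Homo sapiens) for cytotoxicity, read by sulforhodamine B assay, with a stated time of 48 h; on this read-out lower numbers stand for higher toxicity in this test and higher numbers for lower toxicity in this test:

Compound 1, `ClCc1ccccc1Cn1cnc2c(Cl)nc(Cl)nc21`: 6450 nM
Compound 2, `ClCc1cccc(Cn2cnc3ncnc(Cl)c32)c1`: 7410 nM
Compound 3, `ClCc1cccc(Cn2cnc3c(Cl)ncnc32)c1`: 10200 nM

All three share the same arm attached to a fused two-ring core and differ only in how the arm is attached and in how many chloro groups the core carries. On the numbers, compound 3 has the highest value of the three, yet the gap to its nearest neighbour, compound 2, and the gap to the furthest, compound 1, both lie within the scatter of repeated measurements. In practice the three cannot be told apart in this assay.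

Compound 4, `ClCc1cccc(Cn2cnc3c(Cl)nc(Cl)nc32)c1`, is the next to be measured. It differs from compound 3 by chloro in place of hydrogen on an aromatic carbon. For the measured compounds named here, no measured pair shows this exact change, so there is no direct step to lean on. Going by the values given here, the only hint is compound 1, whose core also carries two chloro groups and whose value sits within the scatter of compound 3.

From this, the expected step is a 1.2-fold lower number from compound 3 to compound 4 (0.08 log units; within the scatter), a change no larger than the scatter. Compound 4 is therefore expected to give about 8500 nM, with a likely range from 3500 nM to 20000 nM.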

Compound 4, concentration lethal to 50% of the cells: 8310 nM
For compound 4 the middle estimate is 1.0-fold (0.01 log units) above the measured one; the range from low to high includes it.
By their numbers in this assay, from the lowest: compounds 1, 2, 4 and 3 (each within the scatter of the next).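

Chloro in place of hydrogen on an aromatic carbon, between two ring nitrogen atoms of the six-membered aromatic ring, gives in this assay a step of a 1.2-fold lower number from compound 3 to compound 4 (0.09 log units; within the scatter). For the compounds shown here, this is the first pair in the set that differs in one place only, so this position can now be read directly rather than inferred from compounds that also differ in how the arm is attached, and here the two compounds cannot be told apart in this assay. No separate measurement bears on this result, so the data offer no account of it.

Going by these compounds alone, this single pair tests only one small group at one position, so it remains open whether an amine, a methoxy group or a carboxylic acid at the same carbon would give a step beyond the scatter. Also open, on these data alone, is whether the chloro group would give a similar step on a compound with the arm attached as in compound 1, and whether the same would hold in other cell lines.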